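A few compounds are considered here, and "the series" means these few. Any claim that something is new, unique, unknown or untested is made for them only; others in the source may bear on it.

The measured compounds:
Compound 1, `Nc1ncn(CCC2(N)OC(=O)C(OCc3ccccc3)=C2OCc2ccccc2)c(=O)n1`, gives in a functional assay on SW-620 cells (Homo sapiens) for inhibition, read by MTT assay, with a stated time of 72 h (a lower number here means a stronger inhibitor, a higher number a weaker inhibitor), a value of > 100000 nM, which is a limit of the assay and not a number.
Compound 2, `NC1(CCn2ncc(=O)[nH]c2=O)OC(=O)C(OCc2ccccc2)=C1OCc1ccccc1`, gives in this assay a value of > 100000 nM, likewise a limit.
Compound 3, `NC1(CCn2ccc(=O)[nH]c2=O)OC(=O)C(OCc2ccccc2)=C1OCc1ccccc1`, gives in this assay a value of > 100000 nM, again a limit.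

Compound 3 thus stands at the limit, with no number of its own, and the same holds for the two other measured compounds, as summarised by the limit of > 100000 nM in this assay, at which 3 of the 3 values shown sit. The step to compound 4, `Nc1ccn(CCC2(N)OC(=O)C(OCc3ccccc3)=C2OCc2ccccc2)c(=O)n1`, is a group of 8 heavy atoms (4 carbon, 3 nitrogen, 1 oxygen; one six-membered aromatic ring with 2 hetero atoms) in place of a group of 8 heavy atoms (4 carbon, 2 nitrogen, 2 oxygen; one six-membered aromatic ring with 2 hetero atoms), on a saturated chain carbon, two bonds along the chain from a saturated ring carbon. Three measured steps exchange a ring group at the same place on the chain and so bear on this change: a step that the two limits leave unreadable from compound 1 to compound 2, a step that the two limits leave unreadable from compound 1 to compound 3 and a step that the two limits leave unreadable from compound 2 to compound 3. None of them can be read, since each joins two limits, so no size and no direction can be taken from them. For the measured compounds named here, the only guide is that every exchange of this ring group so far has left the compound at the limit. Compound 4 is therefore expected to remain at the limit, with an estimate of 100000 nM, ranging from 30000 nM to 300000 nM. The step from compound 3 to compound 4 is expected to be a number no higher from compound 3 to compound 4 (the limit leaves the size open), meaning no readable change.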

Compound 4, half-maximal inhibitory concentration: > 100000 nM
Compound 4 ended at the assay's limit; the forecaster's own chance of this, stated with the estimate: 85%; the middle value lies on the limit itself.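

Compound 4 gives only a limit of the assay, as do compound 1, compound 2 and compound 3, so none of the new steps to compound 4 can be read: the limit of > 100000 nM in this assay, at which 4 of the 4 values shown sit.

The compounds shown leave open whether any ring group at this place on the shared core gives a readable number in this assay, and how these ring groups differ.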